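This account rests on a few compounds, and the source may have more. Where it says the series, first, only, none or still open, it means among the compounds named here.

Going by the values given here, in a functional assay on MDA-MB-231 cells (Homo sapiens) for inhibition, read by MTT assay, with a stated time of 72 h (a higher number here means a weaker inhibitor, a lower number a stronger inhibitor), compound 2 `CCc1ccc(NC(=O)CSc2nc(Nc3ccccc3)c3ccccc3n2)cc1` gives 33900 nM, the higher of the two numbers so far, though its gap to compound 1 `O=C(CSc1nc(Nc2ccccc2)c2ccccc2n1)Nc1cccc(Br)c1`, which gives 17500 nM, stays within the scatter. Compound 3 `O=C(CSc1nc(Nc2ccccc2)c2ccccc2n1)Nc1ccc(Cl)c(Cl)c1` carries 3,4-dichlorophenyl in place of 4-ethylphenyl on an amide-type nitrogen. Among the compounds with values here, only one measured step bears on this exchange of groups on the amide-type nitrogen, namely a 1.9-fold higher number from compound 1 to compound 2 (0.29 log units; within the scatter), and it was small. The 3,4-dichlorophenyl of compound 3 resembles the 3-bromophenyl of compound 1 more than the 4-ethylphenyl of compound 2, so a number near compound 1 is expected. The expected step is a 1.9-fold lower number from compound 2 to compound 3 (0.27 log units; within the scatter), not beyond the scatter. Compound 3 is estimated at 18000 nM, between 6000 nM and 50000 nM.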

Compound 3, half-maximal inhibitory concentration: 14500 nM
Compound 3: middle estimate off by 1.2-fold (0.09 log units), on the high side; the measured number falls inside the stated range.
By their numbers in this assay, from the lowest: compounds 3, 1 and 2 (each within the scatter of the next, the first and the last beyond it).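

In this assay, a change on the amide-type nitrogen now produces a step beyond the scatter, a 2.3-fold lower number from compound 2 to compound 3 (0.37 log units; beyond the scatter), which the earlier pair did not show. The 3,4-dichlorophenyl and 3-bromophenyl groups cannot be told apart, at a 1.2-fold lower number from compound 1 to compound 3 (0.08 log units; within the scatter). Nothing available here explains these differences. On these data alone, it remains open whether an amine, a carboxylic acid or a longer chain on this nitrogen, in place of a substituted phenyl, would move the number further. As far as these compounds go, the effect of changes elsewhere on the shared core also remains open.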